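This account rests on a few compounds, and the source may have more. Where it says the series, first, only, none or still open, it means among the compounds named here.

In a functional assay on MDA-MB-231 cells (Homo sapiens) for inhibition, read by CCK-8 assay, with a stated time of 48 h (a lower number here means a stronger inhibitor of growth, a higher number a weaker inhibitor of growth), compound 1 (`CN1CCN(c2ccc(Nc3ncc(Cl)c(NCc4ccc(C(F)(F)F)cc4)n3)nc2)CC1`) gives 19100 nM as its value, compound 2 (`Cc1ccc(CNc2nc(Nc3ccc(N4CCN(C)CC4)cn3)ncc2Cl)cc1`) gives 18600 nM and compound 3 (`COc1ccccc1CNc1nc(Nc2ccc(N3CCN(C)CC3)cn2)ncc1Cl`) gives 29300 nM on the same read-out. Compound 3 cannot be separated from the other two, with a 1.5-fold higher number from compound 1 to compound 3 (0.19 log units; within the scatter) and a 1.6-fold higher number from compound 2 to compound 3 (0.20 log units; within the scatter) as its steps and a 1.0-fold lower number from compound 1 to compound 2 (0.01 log units; within the scatter) between the remaining pair.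

Compound 4 (`CC(C)c1ccccc1Nc1nc(Nc2ccc(N3CCN(C)CC3)cn2)ncc1Cl`) carries 2-isopropylphenyl in place of 2-methoxybenzyl on a nitrogen on an aromatic ring. All three measured steps keep the saturated chain carbon on that nitrogen, so none of them covers this kind of change. They bear on it only loosely. Going by the values given here, with compound 3 reached by steps as small as a 1.6-fold higher number from compound 2 to compound 3 (0.20 log units; within the scatter) and no larger step measured, no step beyond the scatter is expected in this assay and no direction is secured. The estimated change is a 1.8-fold lower number from compound 3 to compound 4 (0.26 log units; within the scatter) and its size remains uncertain. For compound 4 the estimate is 16000 nM with an expected range from 5000 nM to 35000 nM in this series.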

Compound 4, concentration for 50% growth inhibition: 4090 nM
For compound 4 the middle estimate is 3.9-fold (0.59 log units) above the measured one; measured number outside the range, below it.
By their numbers in this assay, from the lowest: compound 4; then compounds 2, 1 and 3 (each within the scatter of the next).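

Across the four compounds in this assay, the change from a benzyl group to 2-isopropylphenyl on the nitrogen on an aromatic ring gives the only steps beyond the scatter: a 7.2-fold lower number from compound 3 to compound 4 (0.86 log units; beyond the scatter) from 2-methoxybenzyl, a 4.5-fold lower number from compound 2 to compound 4 (0.66 log units; beyond the scatter) from 4-methylbenzyl and a 4.7-fold lower number from compound 1 to compound 4 (0.67 log units; beyond the scatter) from 4-(trifluoromethyl)benzyl. The earlier exchanges among the three benzyl groups stayed within the scatter, so this position can respond, and compound 4 is the strongest inhibitor of growth of the four, though only modestly. Nothing available accounts for this gain.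

The change removes the saturated chain carbon and brings in the isopropyl group at once, so the two contributions remain unseparated. Plain phenyl and 2-isopropylbenzyl on the same nitrogen would divide them, while an amine or a longer chain on the ring would test how far the gain extends.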